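This account rests on a few compounds, and the source may have more. Where it says the series, first, only, none or still open, it means among the compounds named here.

Of the compounds shown here, two of the shared core have so far been tested. Compound 1, with the structure `N#CC1=C(N)Oc2c(c3nc4ccccc4nc3c3ccccc23)C12C(=O)N(Cc1cnnn1-c1ccc(Br)cc1)c1ccccc12`, is one of them, and in an ADME assay on L02 cells (Homo sapiens) for antiproliferative activity, read by MTT assay, with a stated time of 48 h (on this read-out lower numbers stand for stronger inhibition and higher numbers for weaker inhibition), compound 1 reaches only the limit of the measurement, > 50000 nM. Compound 2, with the structure `N#CC1=C(N)Oc2c(N)cc3nc4ccccc4nc3c2C12C(=O)N(Cc1cnnn1-c1ccc(Cl)cc1)c1ccccc12`, is the other, and in this assay compound 2 likewise gives only the limit, > 50000 nM. So compound 2 stands at the same place as everything measured here: the limit of > 50000 nM in this assay, at which 2 of the 2 values shown sit. No step between measured compounds is available, and nothing distinguishes compound 2 from compound 1 on the numbers shown.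

Compound 3, with the structure `COc1ccc(-n2nncc2CN2C(=O)C3(C(C#N)=C(N)Oc4c(N)cc5nc6ccccc6nc5c43)c3ccccc32)cc1`, is the next member to be tested. It differs from compound 2 in one place: methoxy in place of chloro on an aromatic carbon. Since both neighbours sit at the limit, no change beyond the scatter is expected from this substitution, and compound 3 is estimated to remain at or near the limit, with an expected step that the limit leaves unreadable from compound 2 to compound 3. The estimate for compound 3 in this assay is 60000 nM, in the range 25000 nM to 150000 nM.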

Compound 3, half-maximal inhibitory concentration: > 50000 nM
Compound 3: a limit, no number; the forecaster's own chance of this, stated with the estimate: 80%; the middle value does not contradict the limit.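

In this assay compound 3 gives > 50000 nM, which is a limit and not a number. Compound 2 also gives only a limit, so no step can be read between compound 2 and compound 3. The compounds shown leave open how any member of the shared core would read as an actual number: the limit of > 50000 nM in this assay, at which 3 of the 3 values shown sit.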